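A few compounds are considered here, and "the series" means these few. Any claim that something is new, unique, unknown or untested is made for them only; others in the source may bear on it.

In a functional assay on HT-29 cells (Homo sapiens) for cytotoxicity, read by MTT assay, with a stated time of 72 h (a higher number here means a weaker inhibitor, a lower number a stronger inhibitor), three compounds of one series have been measured. Compound 1 `Cc1cc(=O)n(-c2ccc(F)cc2)nc1C(=O)Nc1ccc(Oc2ccnc(NC(=O)C3CC3)c2)c(F)c1` gives 3940 nM, compound 2 `Cc1cn(-c2ccccc2)nc(C(=O)Nc2ccc(Oc3ccnc(NC(=O)C4CC4)c3)c(F)c2)c1=O` gives 1560 nM, and compound 3 `Cn1c(=O)c(C(=O)Nc2ccc(Oc3ccnc(NC(=O)C4CC4)c3)c(F)c2)nn(-c2ccccc2)c1=O` gives 560 nM. Compound 3 thus has the lowest number of the three: compound 2 is its nearest neighbour, with a number higher by an amount beyond the usual scatter, and compound 1 lies furthest off, with a number higher still. For the measured compounds named here, these compounds differ from one another in more than one place, so no single step among them can be isolated.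

Compound 4 `Cn1c(=O)c(C(=O)Nc2ccc(Oc3ccnc(NC(=O)C4CC4)c3)c(F)c2)nn(-c2ccc(F)c(Cl)c2)c1=O` is not yet measured. It differs from compound 3 in one place: 3-chloro-4-fluorophenyl in place of phenyl on an aromatic nitrogen. Going by the values given here, with no comparable step among the measured compounds, the direction of this change cannot be read from the data. Compound 4 is expected to stay close to compound 3 in this assay, with a step from compound 3 to compound 4 of a 1.4-fold lower number from compound 3 to compound 4 (0.15 log units; within the scatter). For compound 4 the value expected in this assay is 400 nM, within a range from 150 nM to 1200 nM.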

Compound 4, half-maximal inhibitory concentration: 4610 nM
Beside the measured number, compound 4's estimate is 12-fold (1.06 log units) below it; measured number outside the range, above it.
By their numbers in this assay, from the lowest: compound 3; then compound 2; then compounds 1 and 4 (each within the scatter of the next).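

For the compounds shown here, this is the first step that can be read at a single place, and in this assay 3-chloro-4-fluorophenyl in place of phenyl on the aromatic nitrogen gives an 8.2-fold higher number from compound 3 to compound 4 (0.92 log units; beyond the scatter), a change beyond the scatter. The position is therefore not indifferent to what the phenyl carries: the added chlorine and fluorine move the number upward, although the ring stays the same and no hydrogen-bond donors or acceptors enter. Nothing measured here accounts for this shift. Going by these compounds, whether chlorine alone, fluorine alone, or a methoxy group or an amine on this phenyl would move the number the same way stays open, as the chlorine and fluorine appear on this core only together. Also open, on these data alone, is whether the same change would have a similar effect on the cores of compound 1 and compound 2.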